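Removing the ring methyl from compound 2: an expectation

A few compounds are considered here, and "the series" means these few. Any claim that something is new, unique, unknown or untested is made for them only; others in the source may bear on it.

Compounds measured so far:
- compound 1, `CCCC[C@H](NC(=O)OC(C(C)C)C(C)C)C(=O)C(=O)Nc1ccnn1CCC(C)(C)C`, 1600 nM
- compound 2, `CCCC[C@H](NC(=O)OC(C(C)C)C(C)C)C(=O)C(=O)Nc1[nH]ncc1C`, 5.5 nM

Of the compounds shown here, two have been measured in an assay on isolated protein for inhibition of cathepsin K (Rattus norvegicus); on this read-out lower numbers stand for stronger inhibition and higher numbers for weaker inhibition. Compound 1 gives 1600 nM, while compound 2 gives 5.5 nM, the lower of the two numbers by a margin that lies well beyond the scatter of repeated measurements. On this read-out compound 2 is therefore the stronger inhibitor of the pair.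

Compound 3, `CCCC[C@H](NC(=O)OC(C(C)C)C(C)C)C(=O)C(=O)Nc1cc[nH]n1`, has not yet been measured in this assay. It differs from compound 2 in one place:

1H-pyrazol-3-yl in place of 4-methyl-1H-pyrazol-5-yl on an amide-type nitrogen

Within the data shown here, no pair of measured compounds differing in only this way exists, so the size of the step cannot be read from the data. The change removes one carbon from the ring that sits on the amide-type nitrogen while keeping the hydrogen-bond donor and acceptor count unchanged. A modest loss of potency is expected, with the step of a 2.7-fold higher number from compound 2 to compound 3 (0.44 log units; beyond the scatter) in the direction of a higher number, though it could fall within the scatter. Compound 3 is estimated at 15 nM, with a range from 4 nM to 60 nM.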

Compound 3, half-maximal inhibitory concentration: 13 nM
Compound 3: the middle estimate sits 1.2-fold (0.06 log units) above what was measured; the measured number falls inside the stated range.
By their numbers in this assay, from the lowest: compound 2; then compound 3; then compound 1.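

Read in this assay, the change from 4-methyl-1H-pyrazol-5-yl to 1H-pyrazol-3-yl on the amide-type nitrogen gives a 2.4-fold higher number from compound 2 to compound 3 (0.37 log units; beyond the scatter) and so provides the first step that can be read at this position, a modest one that nevertheless lies beyond the scatter. Compound 3 still gives 13 nM in this assay, which shows that the ring methyl of compound 2 is not needed for a number of this order, although its removal does carry a measurable cost in this pair. Nothing at hand explains the size of this step, and no measurement bears on what lies behind it.

This single pair gives the effect of one ring methyl on one shared core, so it cannot show a trend or say whether the same step would appear if the rest of the molecule were different. On these data alone, how the read-out would respond to an ethyl group, a chlorine atom, a methoxy group or an amine in place of that methyl remains open.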